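Replacing a Hydroxypropoxy Chain with an Aminoethyl Link

The source may report more compounds than this note shows. Statements on the series, on what has been measured and on what is new or still open speak of the compounds shown alone.

Compound 1 `COc1cc(OC)c2c(=O)cc(-c3ccc(OCCF)cc3)oc2c1`: "not active" (no number reported) in a functional assay (Homo sapiens) for antiproliferative activity, read by resazurin assay, with a stated time of 48 h, tested at 10 uM; a lower number here means a weaker effect, a higher number a stronger effect of the compound at the concentration tested
Compound 2 `COc1cc(OC)c2c(=O)cc(-c3ccc(OC4CCNCC4)cc3)oc2c1`: 21%
Compound 3 `COc1cc(OC)c2c(=O)cc(-c3ccc(OCC(O)CN4CCCC4)cc3)oc2c1`: 37%

Compound 3 gives the higher of the two numbers, with compound 2 as the nearest. Among the compounds with values here, the only measured step, a number 16 percentage points higher from compound 2 to compound 3 (beyond the scatter), changed the chain hanging from the same oxygen and shows that this chain matters. Compound 4 `COc1cc(OC)c2c(=O)cc(-c3ccc(NCCN4CCCC4)cc3)oc2c1` differs from compound 3 by (2-(pyrrolidin-1-yl)ethyl)amino in place of 2-hydroxy-3-(pyrrolidin-1-yl)propoxy on an aromatic carbon. The measured step does not cover swapping the oxygen for a nitrogen link or dropping the hydroxyl, so the direction is open; no step beyond the scatter is expected, with wide uncertainty. Compound 4 is estimated at 35%, between 15% and 60%. The expected step is a number 2 percentage points lower from compound 3 to compound 4 (within the scatter).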

Compound 4, a percentage reported as inhibition, at one concentration (the size of the read-out at that concentration, not a potency): 51%
Compound 4: the middle estimate sits 16 percentage points below what was measured; the range from low to high includes it.
By their numbers in this assay, from the lowest: compound 2; then compound 3; then compound 4.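

In this assay the step of a number 14 percentage points higher from compound 3 to compound 4 (beyond the scatter) shows that this aromatic carbon tolerates losing both the oxygen link and the hydroxyl of 2-hydroxy-3-(pyrrolidin-1-yl)propoxy, and that (2-(pyrrolidin-1-yl)ethyl)amino serves better there. The step of a number 30 percentage points higher from compound 2 to compound 4 (beyond the scatter) shows the same group also outdoing (piperidin-4-yl)oxy. No evidence at hand explains these gains.

Going by these compounds, the link atom and the hydroxyl change together, so their separate contributions remain unknown. On these data alone, whether a morpholine in place of the pyrrolidine, or a longer chain before the ring, would raise the inhibition further also stays open.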